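A few compounds are considered here, and "the series" means these few. Any claim that something is new, unique, unknown or untested is made for them only; others in the source may bear on it.

Measured so far in a physicochemical assay for acid dissociation:
compound 1 `Fc1ccc(Cc2ccc3c(NCCCNCc4ccco4)ccnc3c2)c(Cl)c1` gives 9.47
compound 2 `c1coc(CNCCCNc2ccnc3cc(CC4CCCCC4)ccc23)c1` gives 9.47
compound 3 `COc1cccc(CNCCCNc2ccnc3cc(CC4CCCCC4)ccc23)c1O` gives 9.47

Compound 4 `COc1cccc(CNCCCNc2ccnc3cc(Cc4ccc(F)cc4Cl)ccc23)c1O` has not yet been measured in this assay. It differs from compound 3 by 2-chloro-4-fluorophenyl in place of cyclohexyl on a saturated chain carbon bound to an aromatic carbon. The same change has been made once before among these compounds, from compound 2 to compound 1, where 2-chloro-4-fluorophenyl in place of cyclohexyl on a saturated chain carbon bound to an aromatic carbon gave no change at the digits printed from compound 2 to compound 1 (within the scatter). The two cores carrying the change are not identical: compound 3 is set apart from compound 2 by 2-hydroxy-3-methoxyphenyl in place of furan-2-yl on a saturated chain carbon bound to an amine nitrogen, while the place of the change is the same in both pairs. Because no change at the digits printed from compound 2 to compound 1 (within the scatter) lies within the scatter, the step from compound 3 to compound 4 is expected to be no change at the digits printed from compound 3 to compound 4 (within the scatter), matching that earlier step. In this assay compound 4 is therefore estimated at 9.47, expected to fall between 9.2 and 9.75.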

Compound 4, acid dissociation constant: 9.47
Beside the measured number, compound 4's estimate shows no gap at the digits printed; the measured number falls inside the stated range.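

In this assay, 2-chloro-4-fluorophenyl in place of cyclohexyl gives no change at the digits printed from compound 3 to compound 4 (within the scatter) and so matches no change at the digits printed from compound 2 to compound 1 (within the scatter) on the other core, while 2-hydroxy-3-methoxyphenyl in place of furan-2-yl gives no change at the digits printed from compound 1 to compound 4 (within the scatter) as well. A step within the scatter on one core therefore stayed within it on a second core. This covers only two cores and says nothing about any others, and no measurement shown explains why the read-out stays level.

From the compounds shown here alone, all four compounds read alike, so it remains open whether any change moves this number. A carboxylic acid in place of cyclohexyl, or a longer chain joining the two amine nitrogens, could test that.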